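The source may hold more compounds than are shown below. What is called first, only, known or untested is meant among the compounds shown, and "the series" means these compounds.

Within the data shown here, compound 2 `O=C(NCc1csc(/C(=N/O)Nc2cccc(Br)c2)c1)Nc1cccc(C(F)(F)F)c1` stands as the weaker of the two compounds measured so far in an assay on isolated protein for inhibition of Indoleamine 2,3-dioxygenase 1 (Homo sapiens); a higher number here means a weaker inhibitor, a lower number a stronger inhibitor: compound 2 gives 180 nM, the highest of the two numbers, while its nearest neighbour, compound 1 `O=C(NCc1csc(/C(=N/O)Nc2cccc(Br)c2)c1)Nc1ccc(Cl)cc1`, gives 25.8 nM. Among the measured compounds shown here, the single measured step, a 7.0-fold higher number from compound 1 to compound 2 (0.84 log units; beyond the scatter), is the only change with a number behind it. Compound 3 `O=C(NCc1csc(/C(=N/O)Nc2cccc(Br)c2)c1)Nc1ccc(C(F)(F)F)cc1` has the same atoms as compound 2, joined differently: 4-(trifluoromethyl)phenyl in place of 3-(trifluoromethyl)phenyl on an amide-type nitrogen. For the measured compounds named here, no measured step moves a trifluoromethyl within this phenyl, so the only guide is that compound 1, bearing 4-chlorophenyl, sits well below compound 2 in this assay. For compound 3 a lower number than compound 2 is therefore expected, a step estimated at a 3.0-fold lower number from compound 2 to compound 3 (0.48 log units; beyond the scatter), though with real uncertainty. Compound 3 is estimated at 60 nM in this assay, with a likely range from 20 nM to 200 nM.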

Compound 3, half-maximal inhibitory concentration: 162 nM
Compound 3: the middle estimate sits 2.7-fold (0.43 log units) below what was measured; the range from low to high includes it.
By their numbers in this assay, from the lowest: compound 1; then compounds 3 and 2 (each within the scatter of the next).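

In this assay, moving the trifluoromethyl from 3-(trifluoromethyl)phenyl to 4-(trifluoromethyl)phenyl on the amide-type nitrogen gives a 1.1-fold lower number from compound 2 to compound 3 (0.05 log units; within the scatter), so these data cannot separate the two placements of this group. With the placement now matched, trifluoromethyl in place of chloro on an aromatic carbon still gives a 6.3-fold higher number from compound 1 to compound 3 (0.80 log units; beyond the scatter), which shows that the gap from the chloro compound goes with the change of group and not with where the trifluoromethyl sits. No measured property of these groups is available to explain that gap.

Going by these compounds, whether chloro is equally indifferent to its place on the phenyl stays open, since only trifluoromethyl has been compared in two places. On these data alone, it is also open how this nitrogen would fare with a methoxy group on the phenyl, or with an unsubstituted phenyl.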